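Phenyl for Thiophene on a Core Without Measurable Growth Inhibition

A few compounds are considered here, and "the series" means these few. Any claim that something is new, unique, unknown or untested is made for them only; others in the source may bear on it.

The measured compounds:
compound 1, `Cn1cccc1-c1cc(-c2cccs2)nc(N)c1C#N`: > 100000 nM
compound 2, `Cn1cccc1-c1cc(-c2cccs2)[nH]c(=O)c1C#N`: > 100000 nM

In a functional assay on MOLT-4 cells (Homo sapiens) for inhibition, read by sulforhodamine B assay, with a stated time of 48 h (a higher number here means a weaker inhibitor of growth, a lower number a stronger inhibitor of growth), compound 1 gives > 100000 nM, which is a limit of the assay and not a number. Compound 2 likewise gives > 100000 nM in this assay, again a limit. Compound 1 thus stands nowhere in particular among the numbers shown, since both values sit at the limit of > 100000 nM in this assay, at which 2 of the 2 values shown sit, and no compound here has a measured concentration at all.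

The unmeasured compound 3, `Cn1cccc1-c1cc(-c2ccccc2)nc(N)c1C#N`, differs from compound 1 in one place: phenyl in place of thiophen-2-yl on an aromatic carbon. For the measured compounds named here, no step between measured compounds is available to gauge such an exchange. With compound 1 at > 100000 nM in this assay, there is no measured level from which a change of any direction could be read, and the expectation is simply that compound 3 remains at the limit. The expected step of a number no higher from compound 1 to compound 3 (the limit leaves the size open) is accordingly estimated as none beyond the scatter. Compound 3 is therefore expected to come in at about 100000 nM in this assay, within a range of 30000 nM to 300000 nM, most likely reported again only as a limit.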

Compound 3, concentration for 50% growth inhibition: > 100000 nM
Compound 3: only a limit was reported (the forecaster's own chance of this, stated with the estimate: 85%); the middle value lies on the limit itself.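

In this assay compound 3 gives > 100000 nM, a limit of the assay and not a number. For the compounds shown here, no step from compound 1 to compound 3 can be read, since both values are limits: the limit of > 100000 nM in this assay, at which 3 of the 3 values shown sit. The compounds shown leave open what phenyl in place of thiophen-2-yl does to growth inhibition, and what change to the shared core would yield a measured concentration.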